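Nitro substitution on the benzoyl ring of compound 3

A few compounds are considered here, and "the series" means these few. Any claim that something is new, unique, unknown or untested is made for them only; others in the source may bear on it.

Measured compounds in a functional assay on MCF7 cells (Homo sapiens) for cytotoxicity, read by MTT assay, with a stated time of 48 h; on this read-out higher numbers stand for weaker inhibition and lower numbers for stronger inhibition:
- compound 1 `COc1cc(-c2nnc3n2NC(c2cccs2)C(C(=O)c2ccccc2)S3)cc(OC)c1OC`: only a limit, > 100000 nM
- compound 2 `COc1cc(-c2nnc3n2NC(c2cccs2)C(C(=O)c2ccc(F)cc2)S3)cc(OC)c1OC`: 43700 nM
- compound 3 `COc1cc(-c2nnc3n2NC(c2ccco2)C(C(=O)c2ccccc2)S3)cc(OC)c1OC`: 39800 nM

Compound 3 carries the lowest of the two numbers recorded, with compound 2 nearest and within the scatter of it, so the two cannot be placed in order. Compound 1 is recorded only as a limit of this assay (the limit of > 100000 nM in this assay, at which 1 of the 3 values shown sits).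

Compound 4 `COc1cc(-c2nnc3n2NC(c2ccco2)C(C(=O)c2ccc([N+](=O)[O-])cc2)S3)cc(OC)c1OC` is the next member: nitro in place of hydrogen on an aromatic carbon. Going by the values given here, the one measured step at the same place is an at least 2.2-fold lower number from compound 1 to compound 2 (0.35 log units; beyond the scatter), where fluoro entered in place of hydrogen and the number fell beyond the scatter. The step of an at least 2.5-fold lower number from compound 1 to compound 3 (0.40 log units; beyond the scatter) concerns the other ring and is not a guide here. On that single precedent a modest further lowering is expected, though a single step from a limit is thin ground.

Compound 4 is therefore estimated at 20000 nM, within 6000 nM to 60000 nM, which is expected to mean a 2.0-fold lower number from compound 3 to compound 4 (0.30 log units; within the scatter).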

Compound 4, half-maximal inhibitory concentration: > 100000 nM
Compound 4: a limit, no number; the forecaster's own chance of this, stated with the estimate: 10%; middle value at least 5.0-fold (0.69 log units) away from the limit.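

Nitro in place of hydrogen on the benzoyl ring of compound 3 gives an at least 2.5-fold higher number from compound 3 to compound 4 (0.40 log units; beyond the scatter) in this assay, so a change at this position can also raise the number. Compound 4 is recorded only as a limit, not a number, so the size of the rise cannot be read: the limit of > 100000 nM in this assay, at which 2 of the 4 values shown sit.

The earlier step at this position, an at least 2.2-fold lower number from compound 1 to compound 2 (0.35 log units; beyond the scatter), went the other way, so the series shows no single direction for substitution on this ring, though that fluoro step was taken on the thiophen-2-yl member and the nitro step on the furan-2-yl member.

From the compounds shown here alone, it remains open whether the direction follows the entering group or the neighbouring heteroaryl ring, as fluoro appears only with thiophen-2-yl and nitro only with furan-2-yl. Going by these compounds, how an amino group or a carboxylic acid at the same place would read in this assay also remains open.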